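Swapping a Benzylamide for an Anilide on the Chromone

This account rests on a few compounds, and the source may have more. Where it says the series, first, only, none or still open, it means among the compounds named here.

Compound 1 `COc1ccc2c(=O)c(/C=C/C(=O)NCc3cccc(F)c3)coc2c1`: 17600 nM
Compound 2 `COc1ccc2c(=O)c(/C=C/C(=O)NCc3ccc(F)cc3)coc2c1`: > 100000 nM

Both compounds were tested in a functional assay on HeLa cells (Homo sapiens) for inhibition, read by MTT assay, with a stated time of 48 h; on this read-out higher numbers stand for weaker inhibition and lower numbers for stronger inhibition. Compound 1 gives 17600 nM. For compound 2 the assay reports only a limit, > 100000 nM, so its true value is not known beyond that. Going by the values given here, the one measured step is an at least 5.6-fold higher number from compound 1 to compound 2 (0.75 log units; beyond the scatter); it rests on (the limit of > 100000 nM in this assay, at which 1 of the 2 values shown sits), so only its lower bound is firm.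

Compound 3 `COc1ccc(NC(=O)/C=C/c2coc3cc(OC)ccc3c2=O)cc1` differs from compound 2 by 4-methoxyphenyl in place of 4-fluorobenzyl on an amide-type nitrogen. Among the compounds with values here, no measured step touches this change: the step from compound 1 to compound 2 moves a fluorine within the same benzyl group and leaves the saturated chain carbon in place, whereas here that carbon is removed and a methoxy group enters. Compound 2 stands at a limit, which makes any direction hard to anchor. Compound 3 is therefore expected to stay near the weak end, with an estimate of 60000 nM and a range of 15000 nM to 200000 nM. The estimated step of an at least 1.6-fold lower number from compound 2 to compound 3 (0.22 log units; that floor lies within the scatter) should be read as uncertain, since the assay may again report only a limit.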

Compound 3, half-maximal inhibitory concentration: 13000 nM
Beside the measured number, compound 3's estimate is 4.6-fold (0.66 log units) above it; the measured number lies below the stated range.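

Going by these compounds alone, the change of 4-fluorobenzyl to 4-methoxyphenyl on the amide-type nitrogen gives the first measured value for a group joined to that nitrogen without a saturated chain carbon, and in this assay it shows an at least 7.6-fold lower number from compound 2 to compound 3 (0.88 log units; beyond the scatter). Only the lower bound of that step is firm, because compound 2 stands at a limit and not at a number: the limit of > 100000 nM in this assay, at which 1 of the 3 values shown sits. The other new step reads a 1.4-fold lower number from compound 1 to compound 3 (0.13 log units; within the scatter), so 4-methoxyphenyl and 3-fluorobenzyl on this nitrogen cannot be told apart in this assay, and among these three compounds a benzyl group is not needed for a value inside the range of the assay.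

The saturated chain carbon and the methoxy group change together in this swap, and the compounds shown do not separate the two, which a 4-fluorophenyl or a 4-methoxybenzyl group on the same nitrogen could do. From the compounds shown here alone, how the read-out would respond to an amine or a longer chain on the amide-type nitrogen also stays open.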